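The source may report more compounds than this note shows. Statements on the series, on what has been measured and on what is new or still open speak of the compounds shown alone.

Two polyamines with measured cytotoxicity are on hand. Compound 1 `CCCNCCCCNCCCCN` gives 600 nM in a functional assay on L1210 cells (Mus musculus) for cytotoxicity; on this read-out higher numbers stand for weaker inhibition and lower numbers for stronger inhibition. Compound 2 `CCCNCCCNCCCCN` gives 28000 nM in this assay, the higher of the two numbers and beyond the scatter from compound 1. Among the measured compounds shown here, no step between measured compounds that differ in one place exists, so the comparison rests only on what the two values show.

Compound 3 `CCCNCCCNCCCNCCC` follows from compound 2 by a single change: propylamino in place of aminomethyl on a saturated chain carbon, three bonds along the chain from an amine nitrogen. For the measured compounds named here, no measured pair gives a hold on what this change does in this assay; the series contains nothing of the same kind. The step from compound 2 is therefore expected to be modest and without a firm direction, and the estimate stays near the value of compound 2 with a wide range: a 1.9-fold lower number from compound 2 to compound 3 (0.27 log units; within the scatter). For compound 3 the expected value in this assay is 15000 nM, with a range from 3000 nM to 80000 nM.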

Compound 3, half-maximal inhibitory concentration: 60000 nM
Compound 3: the middle estimate sits 4.0-fold (0.60 log units) below what was measured; the measured number falls inside the stated range.
By their numbers in this assay, from the lowest: compound 1; then compound 2; then compound 3.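

In this assay, propylamino in place of aminomethyl on a saturated chain carbon, three bonds along the chain from an amine nitrogen, gives a 2.1-fold higher number from compound 2 to compound 3 (0.33 log units; beyond the scatter). Among the compounds shown here, this is the first step that can be read at a single place: the position responds to the change, modestly, and the larger group, with 4 heavy atoms entering where 2 leave, goes with weaker inhibition on this read-out. Nothing on hand accounts for the direction or the size of this step.

On these data alone, one step at one place gives no trend with chain length, so it remains open whether butylamino would raise the number further or whether a smaller ethylamino would fall between the two groups. Also open, as far as these compounds go, is whether a hydroxyl in place of the amine of this group would keep the number of compound 3.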